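Amide N-substituent variation on the thiazolidinedione naphthalene series

The compounds below may be only part of what the source reports. "The series", "measured", "known", "first", "only" and "open" are said of these compounds alone.

Measured compounds in an assay on isolated protein for inhibition of histone deacetylase 8 (Homo sapiens), with a stated time of 1 h; a lower number here means a stronger inhibitor, a higher number a weaker inhibitor:
- compound 1, `COc1cccc(NC(=O)COc2ccc3cc(/C=C4/SC(=O)NC4=O)ccc3c2)c1`, gives 7600 nM
- compound 2, `Cc1cc(Br)ccc1NC(=O)COc1ccc2cc(/C=C3/SC(=O)NC3=O)ccc2c1`, gives 7400 nM
- compound 3, `O=C(COc1ccc2cc(/C=C3/SC(=O)NC3=O)ccc2c1)Nc1ccc([N+](=O)[O-])cc1`, gives 4000 nM

All three share the same core and differ only in the group on the amide-type nitrogen. Compound 3 stands within the scatter of both neighbours: a 1.9-fold lower number from compound 1 to compound 3 (0.28 log units; within the scatter) and a 1.9-fold lower number from compound 2 to compound 3 (0.27 log units; within the scatter), and the remaining pair shows a 1.0-fold lower number from compound 1 to compound 2 (0.01 log units; within the scatter). None of the three exchanges on this nitrogen moves the number beyond the scatter.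

Compound 4, `Cc1cccc2sc(NC(=O)COc3ccc4cc(/C=C5/SC(=O)NC5=O)ccc4c3)nc12`, is the next member and has not yet been measured in this assay. It differs from compound 3 by 4-methyl-1,3-benzothiazol-2-yl in place of 4-nitrophenyl on an amide-type nitrogen. The three measured steps bear on it directly, as each also exchanges the group on the amide-type nitrogen, and each was within the scatter. On that record no step beyond the scatter is expected in this assay for compound 4 in either direction; the entering group is of a kind not yet covered, so the range is kept wide. The expected step is a 1.1-fold lower number from compound 3 to compound 4 (0.06 log units; within the scatter). Compound 4 is estimated at 3500 nM, with a range from 1200 nM to 10000 nM.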

Compound 4, half-maximal inhibitory concentration: 5800 nM
Beside the measured number, compound 4's estimate is 1.7-fold (0.22 log units) below it; measured number inside the range.
By their numbers in this assay, from the lowest: compounds 3, 4, 2 and 1 (each within the scatter of the next).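

In this assay, the exchange on the amide-type nitrogen now reaches a group with a five-membered aromatic ring holding two hetero atoms: 4-methyl-1,3-benzothiazol-2-yl in place of 4-nitrophenyl gives a 1.5-fold higher number from compound 3 to compound 4 (0.16 log units; within the scatter). Among the compounds shown here, the same group in place of the other two substituents gives a 1.3-fold lower number from compound 2 to compound 4 (0.11 log units; within the scatter) and a 1.3-fold lower number from compound 1 to compound 4 (0.12 log units; within the scatter), so the flat response seen among the three substituted phenyl groups also holds for this group with two aromatic rings, and no compound goes against it among the four. No measurement is available that explains why these exchanges leave the number within the scatter.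

Whether an amine, a carboxylic acid or a longer alkyl chain on this nitrogen would also stay within the scatter remains open, since every group shown here is aromatic and joined directly through a ring carbon. Also open, going by these compounds, is whether replacing the amide hydrogen with methyl, or changing the shared core, would produce a step beyond the scatter in this assay.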